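This account rests on a few compounds, and the source may have more. Where it says the series, first, only, none or still open, it means among the compounds named here.

Working notes, this series. The core of compound 1 `CC(C(=O)NCc1ccc(C(C)(C)C)nc1N1CCCCCC1)c1ccc(NS(C)(=O)=O)c(F)c1` is shared by all three measured compounds; in an assay on cells for antagonist activity at transient receptor potential cation channel subfamily V member 1 (Homo sapiens), read by FLIPR and calcium flux, with a stated time of 6 min (on this read-out lower numbers stand for stronger inhibition and higher numbers for weaker inhibition), compound 1 gives 0.9 nM. Compound 2 `CC(C(=O)NCc1ccc(C(C)(C)C)nc1OCc1ccccc1)c1ccc(NS(C)(=O)=O)c(F)c1` gives 4.4 nM in this assay, and compound 3 `CC(C(=O)NCc1ccc(C(C)(C)C)nc1OCc1ccc(F)cc1)c1ccc(NS(C)(=O)=O)c(F)c1` gives 0.8 nM. Compound 3 holds the lowest of the three numbers; compound 1 is nearest and within the scatter of it, compound 2 is furthest. The measured steps are a 4.9-fold higher number from compound 1 to compound 2 (0.69 log units; beyond the scatter), a 1.1-fold lower number from compound 1 to compound 3 (0.05 log units; within the scatter) and a 5.5-fold lower number from compound 2 to compound 3 (0.74 log units; beyond the scatter).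

Compound 4 `COc1ccc(CSc2nc(C(C)(C)C)ccc2CNC(=O)C(C)c2ccc(NS(C)(=O)=O)c(F)c2)cc1` is not yet measured in this assay. It differs from compound 3 in one place: (4-methoxybenzyl)sulfanyl in place of (4-fluorobenzyl)oxy on an aromatic carbon. Within the data shown here, the step of a 5.5-fold lower number from compound 2 to compound 3 (0.74 log units; beyond the scatter) bears on it, since it shows that the group on the ring of the benzyl changes the number beyond the scatter; no measured step covers the exchange of the oxygen link for the sulfanyl link, so that part is open. A small to modest rise in the number is expected, in this assay a 2.5-fold higher number from compound 3 to compound 4 (0.40 log units; beyond the scatter), with a wide range. Compound 4 is therefore estimated at 2 nM in this assay, between 0.5 nM and 8 nM.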

Compound 4, inhibition constant: 3.5 nM
Compound 4: the middle estimate sits 1.8-fold (0.24 log units) below what was measured; measured number inside the range.
By their numbers in this assay, from the lowest: compounds 3 and 1 (each within the scatter of the next); then compounds 4 and 2 (each within the scatter of the next).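

At this position, next to the ring nitrogen, (4-methoxybenzyl)sulfanyl in place of (4-fluorobenzyl)oxy gives a 4.4-fold higher number from compound 3 to compound 4 (0.64 log units; beyond the scatter) in this assay, and in place of azepan-1-yl it gives a 3.9-fold higher number from compound 1 to compound 4 (0.59 log units; beyond the scatter). Against benzyloxy it gives a 1.3-fold lower number from compound 2 to compound 4 (0.10 log units; within the scatter), which lies within the scatter, so a sulfanyl-linked benzyl group stays inside the span of values set by the earlier compounds. Nothing measured on these compounds accounts for these steps.

Compound 4 changes the link and the ring substituent together, so the share of each in its step from compound 3 stays unresolved; the (4-fluorobenzyl)sulfanyl and (4-methoxybenzyl)oxy groups would separate them. The compounds shown also leave open how a benzylamino link or a pyrrolidin-1-yl group would read at this position.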